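Hybrid hydrazone from two inactive thiazoles: what to expect

This account rests on a few compounds, and the source may have more. Where it says the series, first, only, none or still open, it means among the compounds named here.

Measured so far:
compound 1 `Fc1ccc(/C=N/Nc2nc(-c3cc(C(F)(F)F)cc(C(F)(F)F)c3)cs2)cc1F` — > 100000 nM
compound 2 `COc1cc(/C=N/Nc2nc(-c3cccc(Br)c3)cs2)cc(Br)c1OC` — > 100000 nM

In an ADME assay on HUVEC cells (Homo sapiens) for inhibition, read by MTT assay, with a stated time of 48 h (on this read-out lower numbers stand for stronger inhibition and higher numbers for weaker inhibition), compound 1 gives > 100000 nM, which is a limit of the assay and not a measured number. Compound 2 gives > 100000 nM in this assay, again a limit. Both values thus sit at the limit of > 100000 nM in this assay, at which 2 of the 2 values shown sit, so compound 1 cannot be ranked against compound 2 on these numbers: neither shows any measurable inhibition.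

Compound 3 `COc1cc(/C=N/Nc2nc(-c3cc(C(F)(F)F)cc(C(F)(F)F)c3)cs2)cc(Br)c1OC` has not yet been measured. It differs from compound 1 by 3-bromo-4,5-dimethoxyphenyl in place of 3,4-difluorophenyl on a carbon with a double bond to nitrogen, so it pairs the bis(trifluoromethyl)phenyl of compound 1 with the hydrazone-side aryl of compound 2. Among the measured compounds shown here, no step between measured compounds is available to guide the size of this change. Since each of the two parent compounds stays at the limit, the step from compound 1 to compound 3 is expected to be a step that the limit leaves unreadable from compound 1 to compound 3, that is, nothing beyond the usual scatter. Compound 3 is expected to give about 150000 nM, within 30000 nM to 1000000 nM, most probably reported again only as a limit.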

Compound 3, half-maximal inhibitory concentration: > 100000 nM
Compound 3: a limit, no number; the forecaster's own chance of this, stated with the estimate: 80%; the middle value does not contradict the limit.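

No step can be read from compound 1 to compound 3 in this assay, because both values are limits of the assay and not numbers: the limit of > 100000 nM in this assay, at which 3 of the 3 values shown sit.

The compounds shown leave open how far apart compound 1, compound 2 and compound 3 really lie, and whether any of them would give a measured number in this assay.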